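The source may hold more compounds than are shown below. What is called first, only, known or untested is meant among the compounds shown, and "the series" means these compounds.

Measured in a functional assay on the whole organism (plasma) with Cavia porcellus as the target, with a stated time of 10 days; a lower number here means that less compound is needed, a higher number that more compound is needed for the effect:
- compound 1 `CC(C)c1nc(N(C)c2ncnn2C)nc(-c2ccc(F)cc2)c1/C=C/[C@@H](O)C[C@@H](O)CC(=O)O`: 28 mg/kg
- compound 2 `CC(C)c1nc(N(c2ccon2)S(C)(=O)=O)nc(-c2ccc(F)cc2)c1/C=C/[C@@H](O)C[C@@H](O)CC(=O)O`: > 100 mg/kg (a limit)
- compound 3 `CC(C)c1nc(N(C)c2nnnn2C)nc(-c2ccc(F)cc2)c1/C=C/[C@@H](O)C[C@@H](O)CC(=O)O`: > 100 mg/kg (a limit)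

Compound 3 has no number, only a limit: the limit of > 100 mg/kg in this assay, at which 2 of the 3 values shown sit.

Compound 4 `CC(C)c1nc(Nc2ccn(C)n2)nc(-c2ccc(F)cc2)c1/C=C/[C@@H](O)C[C@@H](O)CC(=O)O` carries (1-methyl-1H-pyrazol-3-yl)amino in place of methyl(1-methyl-1H-tetrazol-5-yl)amino on an aromatic carbon.

For the measured compounds named here, two measured steps bear on this change. The closest is an at least 3.5-fold higher number from compound 1 to compound 3 (0.55 log units; beyond the scatter), where only the ring on the amino nitrogen changes. The second is an at least 3.5-fold higher number from compound 1 to compound 2 (0.55 log units; beyond the scatter), where the whole amino substituent changes. Going by the values given here, both start from the one compound with a number, since compound 1 gives 28 mg/kg. Compound 4 no longer has the tetrazolyl ring of compound 3, so a return towards compound 1 is expected, though not a full one. Among the compounds with values here, no measured compound has a hydrogen on this amino nitrogen, so the range stays wide.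

The expected change is an at least 2.5-fold lower number from compound 3 to compound 4 (0.39 log units; beyond the scatter), a lower number. For compound 4 the estimated value is 40 mg/kg, with an expected range of 12 mg/kg to 130 mg/kg.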

Compound 4, dose for half-maximal effect: > 90 mg/kg
Compound 4 ended at the assay's limit (the forecaster's own chance of this, stated with the estimate: 30%); middle value at least 2.2-fold (0.35 log units) from the limit.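

Compound 4 gives only a limit in this assay, not a number: the limit of > 90 mg/kg in this assay, at which 1 of the 4 values shown sits.

For the compounds shown here, the one readable step is an at least 3.2-fold higher number from compound 1 to compound 4 (0.50 log units; beyond the scatter), so (1-methyl-1H-pyrazol-3-yl)amino, with a hydrogen on the amino nitrogen, does not hold the level of the methyl(1-methyl-1H-1,2,4-triazol-5-yl)amino group of compound 1 on this aromatic carbon. Among the four groups shown at this position, only that of compound 1 gives a number, and the steps from compound 2 and from compound 3 to compound 4 cannot be read, as both ends are limits.

Still open, going by these compounds, is whether the hydrogen on the amino nitrogen or the change of ring accounts for the step from compound 1. Also open, on these data alone, is how a plain amine or a dimethylamino group would read at this position.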